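Following a change on compound 3 in cell growth inhibition

The compounds below may be only part of what the source reports. "The series", "measured", "known", "first", "only" and "open" are said of these compounds alone.

Measured compounds:
Compound 1 `CC(C)n1ncc2c(C(=O)Nc3cccnc3)cccc21` gives in a functional assay on MCF7 cells (Homo sapiens) for inhibition, read by MTT assay, with a stated time of 72 h (on this read-out lower numbers stand for stronger inhibition and higher numbers for weaker inhibition), only a limit, > 40000 nM.
Compound 2 `CC(C)n1ncc2c(C(=O)NCc3ccccc3)cccc21` gives in this assay only a limit, > 40000 nM.
Compound 3 `Cc1ccc(-n2cc(CNC(=O)c3cccc4c3cnn4C(C)C)nn2)c(C)c1` gives in this assay only a limit, > 40000 nM.

None of these three values is a number; each is the limit of the measurement, and compound 3 sits at the same limit as the other two (the limit of > 40000 nM in this assay, at which 3 of the 3 values shown sit). For the measured compounds named here, the one step between measured compounds that differ in a single place, a step that the two limits leave unreadable from compound 1 to compound 2, cannot be read either, since both of its ends are limits. Compound 4 `CC(C)n1ncc2c(C(=O)NCc3cn(-c4cccc(Br)c4)nn3)cccc21` differs from compound 3 by 3-bromophenyl in place of 2,4-dimethylphenyl on an aromatic nitrogen. No measured step touches this part of the molecule, so nothing in the numbers shown points to a direction or to a size beyond the usual scatter. The estimate for compound 4 is therefore that it stays where compound 3 stands: an expected value of 40000 nM, with a range from 20000 nM to 80000 nM. The expected step of a number no higher from compound 3 to compound 4 (the limit leaves the size open) is, on this estimate, no more than the scatter.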

Compound 4, half-maximal inhibitory concentration: > 40000 nM
Compound 4: only a limit was reported; the forecaster's own chance of this, stated with the estimate: 85%; the middle value lies on the limit itself.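

Compound 3 and compound 4 each give a limit of the measurement rather than a number, so no step between them can be read: the limit of > 40000 nM in this assay, at which 4 of the 4 values shown sit.

Still open, as far as these compounds go, is how strongly any of the four compounds acts in this assay, and whether the group on the aromatic nitrogen matters there at all.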